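Chloro for trifluoromethyl on the benzyl ring, cyclopropyl series

The source may report more compounds than this note shows. Statements on the series, on what has been measured and on what is new or still open speak of the compounds shown alone.

Of the compounds shown here, three of the shared core have been measured in an assay on isolated protein for binding affinity to adenosine receptor A1 (Bos taurus); on this read-out higher numbers stand for weaker inhibition and lower numbers for stronger inhibition. Compound 1 `Clc1ccccc1Cn1nnc2c(NC3CCCCC3)nc(-c3ccccc3)nc21` gives 34000000 nM. Going by the values given here, compound 2 `OCCCNc1nc(-c2ccccc2)nc2c1nnn2Cc1ccccc1Cl` gives 33000000 nM; the only measured single-point step, a 1.0-fold lower number from compound 1 to compound 2 (0.01 log units; within the scatter), shows that exchanging the amine substituent with the 2-chlorophenyl held fixed changes nothing measurable. Compound 3 `FC(F)(F)c1ccccc1Cn1nnc2c(NC3CC3)nc(-c3ccccc3)nc21` gives 7800000 nM, the lowest of the three numbers; compound 2 sits at a higher number and compound 1 at a still higher one, both gaps beyond the scatter.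

Compound 4 `Clc1ccccc1Cn1nnc2c(NC3CC3)nc(-c3ccccc3)nc21` is to be measured in this assay. Its difference from compound 3 is chloro in place of trifluoromethyl on an aromatic carbon. Among the compounds with values here, no measured pair differs by this exchange, so no step bears on it directly; compound 1 and compound 2 carry the 2-chlorophenyl but differ from compound 4 in the amine substituent as well, and compound 3 differs from them in two places. The available values therefore leave the direction open. A working expectation is that compound 4 moves toward the range of compound 1 and compound 2, a step of a 1.8-fold higher number from compound 3 to compound 4 (0.25 log units; within the scatter) in this assay, with a wide margin. Compound 4 is estimated at 14000000 nM, within the range 3500000 nM to 56000000 nM.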

Compound 4, inhibition constant: 11000000 nM
For compound 4 the middle estimate is 1.3-fold (0.10 log units) above the measured one; the range from low to high includes it.
By their numbers in this assay, from the lowest: compounds 3 and 4 (each within the scatter of the next); then compounds 2 and 1 (each within the scatter of the next).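

In this assay the 2-(trifluoromethyl)phenyl to 2-chlorophenyl exchange can now be read directly with the cyclopropyl substituent held fixed (a 1.4-fold higher number from compound 3 to compound 4 (0.15 log units; within the scatter)), and replacing four heavy atoms with one leaves the two compounds within the scatter at this position. The amine substituent, which gave no readable difference between cyclohexyl and 3-hydroxypropyl, now gives modest steps beyond the scatter with the 2-chlorophenyl held fixed (a 3.0-fold lower number from compound 2 to compound 4 (0.48 log units; beyond the scatter); a 3.1-fold lower number from compound 1 to compound 4 (0.49 log units; beyond the scatter)), so among these three substituents, cyclopropyl gives the lowest number in this series. No measured property of these compounds bears on either result, and the data offer no explanation for them.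

Going by these compounds, it remains open whether the equivalence of chloro and trifluoromethyl extends to other amine substituents, such as cyclohexyl or 3-hydroxypropyl, or to other groups on this aromatic carbon, such as fluoro, methoxy or nitrile. On these data alone, it is also open whether the low number belongs to cyclopropyl specifically or extends to a cyclobutyl, a cyclopentyl or a short unbranched chain such as ethyl on the same nitrogen.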